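The source may hold more compounds than are shown below. What is called first, only, known or untested is meant among the compounds shown, and "the series" means these compounds.

Compound 1 `Cc1ccc(N2CCN(CCCOc3ccc4c(=O)cc(-c5ccccc5)oc4c3)CC2)cc1` is the reference point of this set. In a functional assay for antagonist activity at Adrenergic receptor alpha-1 (Rattus norvegicus) (on this read-out lower numbers stand for tighter binding and higher numbers for weaker binding), compound 1 gives 20.7 nM, the second highest of the three numbers measured. Compound 3 `Cc1ccccc1N1CCN(CCCCOc2ccc3c(=O)cc(-c4ccccc4)oc3c2)CC1` gives 19.5 nM in this assay, which sits within the scatter of compound 1, so the two cannot be ordered. Among the compounds with values here, compound 2 `Cc1ccccc1N1CCN(CCCOc2ccc3c(=O)cc(-c4ccccc4)oc3c2)CC1` gives 117 nM; the step of a 5.7-fold higher number from compound 1 to compound 2 (0.75 log units; beyond the scatter) is the only change measured so far and it concerns the methylphenyl on the ring nitrogen, not the phenyl on the shared core.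

Compound 4 `Cc1ccc(N2CCN(CCCOc3ccc4c(=O)cc(-c5ccc(Cl)cc5)oc4c3)CC2)cc1` differs from compound 1 by chloro in place of hydrogen on an aromatic carbon. Within the data shown here, no measured step touches that phenyl ring, so nothing here speaks for a shift; a step within the scatter is expected, a 1.0-fold lower number from compound 1 to compound 4 (0.01 log units; within the scatter). For compound 4 the expected value in this assay is 20 nM, with a range of 7 nM to 55 nM.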

Compound 4, dissociation constant: 8.17 nM
Compound 4: the middle estimate sits 2.4-fold (0.39 log units) above what was measured, within the range that was stated.
By their numbers in this assay, from the lowest: compound 4; then compounds 3 and 1 (each within the scatter of the next); then compound 2.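

The phenyl on the shared core is not silent: chloro in place of hydrogen on an aromatic carbon, para to a large group, gives a 2.5-fold lower number from compound 1 to compound 4 (0.40 log units; beyond the scatter) in this assay. Within the data shown here, this is the first measured change at this ring, and phenyl to 4-chlorophenyl moves the number towards tighter binding. Nothing on hand accounts for the step. On these data alone, whether fluoro, bromo or methoxy at this position would move the number the same way remains open. So does whether 4-chlorophenyl gives a similar step on the 2-methylphenyl compounds, compound 2 and compound 3.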